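Ethyl in place of methyl on a carboxy analogue

A few compounds are considered here, and "the series" means these few. Any claim that something is new, unique, unknown or untested is made for them only; others in the source may bear on it.

Measured compounds:
compound 1, `Cc1ccc2nc(C(=O)Nc3c(F)cc(-c4cccc(F)c4)cc3F)c(C)c(O)c2c1`, 26.5%
compound 2, `CCc1ccc2nc(C(=O)Nc3c(F)cc(-c4cccc(F)c4)cc3F)c(C)c(O)c2c1`, 28.4%
compound 3, `Cc1ccc2nc(C(=O)Nc3c(F)cc(-c4cccc(F)c4)cc3F)c(C)c(C(=O)O)c2c1`, 26.3%

Of the compounds shown here, three sharing one core have been measured in a functional assay on A-375 cells (Homo sapiens) for antiproliferative activity, read by MTT assay, with a stated time of 24 h, tested at 33.33 ug/mL; on this read-out higher numbers stand for a stronger effect at the one concentration tested and lower numbers for a weaker effect. Compound 1 gives 26.5%, compound 2 gives 28.4% and compound 3 gives 26.3%. Compound 3 stands within the scatter of both others: a number 0.2 percentage points lower from compound 1 to compound 3 (within the scatter), so the carboxy in place of hydroxy on an aromatic carbon changed nothing that can be told from the hydroxy parent.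

Compound 4, `CCc1ccc2nc(C(=O)Nc3c(F)cc(-c4cccc(F)c4)cc3F)c(C)c(C(=O)O)c2c1`, has not been measured. It differs from compound 3 by methyl in place of hydrogen on a saturated chain carbon bound to an aromatic carbon. The same change has been seen once, on the hydroxy pair: a number 1.9 percentage points higher from compound 1 to compound 2 (within the scatter). That step is the only one that bears on the present one, and it lay within the scatter. The expectation is therefore that compound 4 shows no step beyond the scatter, and the expected step is a number 1.2 percentage points higher from compound 3 to compound 4 (within the scatter). Compound 4 is estimated to give 27.5%, with a range from 17% to 38%.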

Compound 4, a percentage reported as inhibition, at one concentration (the size of the read-out at that concentration, not a potency): 47.1%
Estimate against measurement, compound 4: 19.6 percentage points below; measured number above the stated range.
By their numbers in this assay, from the lowest: compounds 3, 1 and 2 (each within the scatter of the next); then compound 4.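

In this assay the methyl-to-ethyl change proves to depend on its surroundings: with the carboxy group present it gives a number 20.8 percentage points higher from compound 3 to compound 4 (beyond the scatter), while on the hydroxy pair it moved nothing that could be told, so this position does not respond alike on the two cores: the same change on two cores in this assay, a number 1.9 percentage points higher (within the scatter) from compound 1 to compound 2 and a number 20.8 percentage points higher (beyond the scatter) from compound 3 to compound 4, 18.9 percentage points apart, beyond the scatter of two such steps. Read the other way, carboxy in place of hydroxy on an aromatic carbon, silent with the methyl present, shows itself with the ethyl present, as a number 18.7 percentage points higher from compound 2 to compound 4 (beyond the scatter): the same change on two cores in this assay, a number 0.2 percentage points lower (within the scatter) from compound 1 to compound 3 and a number 18.7 percentage points higher (beyond the scatter) from compound 2 to compound 4, 18.9 percentage points apart, beyond the scatter of two such steps. On these compounds, then, neither change alone gave a step beyond the scatter, and only their combination did.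

The read-out comes from a single concentration, so it shows a stronger effect of compound 4 at that concentration and nothing about other concentrations. The compounds shown also do not tell whether a propyl chain at this place, or an amide in place of the carboxy group, would keep the higher number.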